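Swapping fluoro for trifluoromethyl on a low-toxicity series

The source may hold more compounds than are shown below. What is called first, only, known or untested is meant among the compounds shown, and "the series" means these compounds.

Values measured in an ADME assay on L02 cells (Homo sapiens) for cytotoxicity, read by MTT assay, with a stated time of 24 h; a higher number here means a weaker inhibitor, a lower number a stronger inhibitor:
Compound 1 `O=C1/C(=C/c2ccncc2)CNC/C1=C\c1ccccc1F`: 14700 nM
Compound 2 `Cc1ccc(S(=O)(=O)N2C/C(=C\c3ccncc3)C(=O)/C(=C/c3ccccc3F)C2)cc1`: > 20000 nM
Compound 3 `O=C1/C(=C/c2ccncc2)CN(S(=O)(=O)c2ccc(C(F)(F)F)cc2)C/C1=C\c1ccccc1F`: 18600 nM

Compound 2 reads > 20000 nM, and this is a limit of the assay, not a number. Its true position on the scale is therefore unknown, and any step starting from compound 2 has only a floor.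

Compound 4 `Cc1ccc(S(=O)(=O)N2C/C(=C\c3ccncc3)C(=O)/C(=C/c3ccccc3C(F)(F)F)C2)cc1` differs from compound 2 in one place: trifluoromethyl in place of fluoro on an aromatic carbon. The 2-fluorophenyl group becomes a 2-(trifluoromethyl)phenyl group, while the rest of compound 2 stays as it is.

Going by the values given here, no measured step replaces fluoro, so the available evidence is indirect. Placing the sulfonyl group on the ring nitrogen gave an at least 1.3-fold higher number from compound 1 to compound 2 (0.13 log units; that floor lies within the scatter). Putting trifluoromethyl in place of methyl, at a different aromatic carbon, gave an at least 1.0-fold lower number from compound 2 to compound 3 (0.03 log units; that floor lies within the scatter). Both floors lie within the scatter, so neither shows a clear effect. No step beyond the scatter is therefore expected in this assay, and no direction can be named with confidence. The expected step is an at least 1.0-fold lower number from compound 2 to compound 4 (0.02 log units; that floor lies within the scatter). For compound 4 the estimate is 19000 nM, with an expected range from 10000 nM to 40000 nM.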

Compound 4, half-maximal inhibitory concentration: 12800 nM
Compound 4: the middle estimate sits 1.5-fold (0.17 log units) above what was measured; measured number inside the range.
By their numbers in this assay, from the lowest: compounds 4, 1 and 3 (each within the scatter of the next). At a limit, above all of these: compound 2.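

Going by these compounds alone, earlier steps changed only the ring nitrogen and the group on the sulfonyl, so this is the first look at the 2-fluorophenyl group in this assay, and moving to 2-(trifluoromethyl)phenyl gives an at least 1.5-fold lower number from compound 2 to compound 4 (0.19 log units; that floor lies within the scatter). This step is only a floor because compound 2 sits at a limit of the assay: the limit of > 20000 nM in this assay, at which 1 of the 4 values shown sits. On these data alone, the floor shows no clear effect of the larger group, but the true size of the step remains unknown. Compound 4, at 12800 nM, gives this position its first exact number with the (4-methylphenyl)sulfonyl group in place.

Fluoro and trifluoromethyl are the only groups shown at this position, so it remains open how a chlorine atom, a methoxy group or an amine would read there in this assay. As far as these compounds go, it is also open whether the same swap would give a similar result with the free ring nitrogen of compound 1 or with the sulfonyl group of compound 3, and whether it would matter in a test other than this one on L02 cells.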